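From fluoro to nitro: working notes on compound 3

The source may report more compounds than this note shows. Statements on the series, on what has been measured and on what is new or still open speak of the compounds shown alone.

In a functional assay on MDA-MB-231 cells (Homo sapiens) for antiproliferative activity, read by sulforhodamine B assay, with a stated time of 48 h (on this read-out lower numbers stand for stronger inhibition and higher numbers for weaker inhibition), compound 1 (`COc1cc(OC)c2sc(-c3ccc(N/C=C\C(=O)c4ccc(OC)c([N+](=O)[O-])c4)c(C)c3)nc2c1`) gives 10800 nM while compound 2 (`COc1ccc(C(=O)/C=C\Nc2ccc(-c3nc4cc(OC)c(OC)c(OC)c4s3)cc2C)cc1F`) gives 2900 nM as the lower of the two numbers, a gap beyond the usual scatter. Compound 3 (`COc1ccc(C(=O)/C=C\Nc2ccc(-c3nc4cc(OC)c(OC)c(OC)c4s3)cc2C)cc1[N+](=O)[O-]`) follows from compound 2 by one change: nitro in place of fluoro on an aromatic carbon describes nitro in place of fluoro on an aromatic carbon, ortho to a methoxy group, so that 3-fluoro-4-methoxyphenyl becomes 4-methoxy-3-nitrophenyl. Going by the values given here, no measured pair isolates this change. Among the compounds with values here, compound 1, the only measured compound holding a nitro group, gives 10800 nM on the weaker side of compound 2, which is thin support for a direction. In this assay the estimated step of a 1.6-fold higher number from compound 2 to compound 3 (0.19 log units; within the scatter) is an expected small move towards weaker inhibition, possibly none beyond the scatter. For compound 3 the estimate is 4500 nM with an expected range from 1300 nM to 15000 nM as the working figure.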

Compound 3, half-maximal inhibitory concentration: 12400 nM
Estimate against measurement, compound 3: 2.8-fold (0.44 log units) below; low and high end bracket the measured number.
By their numbers in this assay, from the lowest: compound 2; then compounds 1 and 3 (each within the scatter of the next).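

In this assay the position ortho to a methoxy group now has a matched pair, and the change from 3-fluoro-4-methoxyphenyl to 4-methoxy-3-nitrophenyl gives a 4.3-fold higher number from compound 2 to compound 3 (0.63 log units; beyond the scatter) on the shared core, so nitro here goes with weaker inhibition than fluoro. With the nitro group held constant, methoxy in place of hydrogen on an aromatic carbon of the core gives a 1.1-fold higher number from compound 1 to compound 3 (0.06 log units; within the scatter) and so shows no change that can be read. Nothing measured here accounts for the step from fluoro to nitro.

On these data alone, whether an amine or a nitrile at this position would match fluoro or nitro remains open. As far as these compounds go, the size of the fluoro-to-nitro step on the core of compound 1 also remains open.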